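The source may report more compounds than this note shows. Statements on the series, on what has been measured and on what is new or still open speak of the compounds shown alone.

Measured so far:
compound 1, `COc1cccc(NC(=S)Nc2cccc(C(F)(F)F)c2)c1`, 26000 nM
compound 2, `O=C(NC(=S)Nc1cccc(C(F)(F)F)c1)[C@H]1C[C@@H]2CC[C@H]1C2`, 42000 nM

Two thioureas of the series carry a number in an ADME assay on MT4 cells (Homo sapiens) for cytotoxicity; a higher number here means that more compound is tolerated, a lower number that less compound is tolerated. Compound 1 gives 26000 nM. Compound 2 gives 42000 nM. The gap between compound 2 and compound 1 lies within the scatter of repeated measurements, so neither compound stands apart from the other, and compound 2 cannot be said to be better or worse tolerated than compound 1 on these two numbers alone.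

Compound 3, `O=C(NC(=S)Nc1cccc(C(F)(F)F)c1)c1ccccc1`, has not yet been measured in this assay. It differs from compound 2 at one place only:
a group of 6 heavy atoms (6 carbon; one six-membered aromatic ring of carbon only) in place of a group of 7 heavy atoms (7 carbon; 2 five-membered non-aromatic rings of carbon only), on a carbonyl carbon
Among the compounds with values here, no measured pair shows this kind of change, so there is no step to compare against. The two numbers in hand sit close together despite unrelated groups on the shared core, which gives no ground to expect a shift beyond the scatter. Compound 3 is therefore expected to land near compound 2, with the step from compound 2 to compound 3 estimated at a 1.3-fold lower number from compound 2 to compound 3 (0.12 log units; within the scatter). The estimated value for compound 3 is 32000 nM, within a range from 12000 nM to 85000 nM.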

Compound 3, half-maximal cytotoxic concentration: > 100000 nM
Compound 3 was reported as a limit; the forecaster's own chance of this, stated with the estimate: 25%; at least 3.1-fold (0.49 log units) between middle value and limit.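

Within the data shown here, on a carbonyl carbon whose other neighbours are amide-type nitrogen, this pair gives the first single-place change that can be read, and it lies beyond the scatter in this assay: phenyl in place of the group with 2 five-membered non-aromatic rings of carbon only gives an at least 2.3-fold higher number from compound 2 to compound 3 (0.37 log units; beyond the scatter). For compound 3 the value > 100000 nM is a limit of the assay, and the step therefore gives only a lower bound on the change: the limit of > 100000 nM in this assay, at which 1 of the 3 values shown sits. The carbonyl carbon is thus a place where the choice of group shows up in this assay, which the earlier two compounds could not show, as they differ in more than one place.

One pair cannot separate what phenyl brings from what leaves with the two non-aromatic rings and their 3 defined stereocentres, and it gives no cause for the step. The compounds shown also leave open whether the same direction holds for a pyridine ring, a phenyl ring carrying a carboxylic acid, or an open butyl chain on this carbonyl carbon.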